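The source may hold more compounds than are shown below. What is called first, only, known or untested is meant among the compounds shown, and "the series" means these compounds.

Measured so far:
- compound 1 `O=C(NCc1cccc(Cl)c1)c1ccc2cn(CCN3CCOC3=O)nc2c1` — 220 nM
- compound 2 `COc1cc(C(=O)N2CCC(O)C(C)C2)cc2nc(NCc3cc(Cl)ccc3F)oc12` — 300 nM

Both values come from an assay on isolated protein for inhibition of thyroid hormone receptor beta (Homo sapiens), read by fluorescence, with a stated time of 30 min; a higher number here means a weaker inhibitor, a lower number a stronger inhibitor. Compound 1 gives 220 nM in this assay, and compound 2 gives 300 nM. The two numbers sit within the usual scatter of each other, so neither compound is placed above the other; compound 2 and compound 1 count as equivalent on the data so far. Going by the values given here, the two cores are different, and no single-point step between them is defined, so nothing about the size of a substituent effect can be read from the pair.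

Compound 3 `COc1cc(C(=O)N2CCC(O)C(C)C2)cc2nc(NC3(c4cccc(Cl)c4)CCC3)oc12` is the untested analogue of compound 2. The change is 1-(3-chlorophenyl)cyclobutyl in place of 5-chloro-2-fluorobenzyl on a nitrogen on an aromatic ring. Among the compounds with values here, no measured step of comparable kind exists, so the expected effect rests on the change alone. The step from compound 2 to compound 3 is expected to be small, leaning toward a weaker inhibitor if anything, and not clearly beyond the scatter: a 1.7-fold higher number from compound 2 to compound 3 (0.22 log units; within the scatter). For compound 3 in this assay the estimate is 500 nM, with a plausible range from 150 nM to 2000 nM.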

Compound 3, half-maximal inhibitory concentration: 8200 nM
The estimate for compound 3 lay 16-fold (1.21 log units) below the measured number, outside the stated range (above it).
By their numbers in this assay, from the lowest: compounds 1 and 2 (each within the scatter of the next); then compound 3.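

In this assay, 1-(3-chlorophenyl)cyclobutyl in place of 5-chloro-2-fluorobenzyl on a nitrogen on an aromatic ring gives a 27-fold higher number from compound 2 to compound 3 (1.44 log units; beyond the scatter) and marks this position as one where a single change can move the number well beyond the scatter. Going by these compounds alone, this is the first step that differs in one place, since the earlier pair offered no such reading, and the rest of compound 2 stays the same in compound 3. The exchange still alters several things together, as the fluorine leaves and a four-membered non-aromatic ring of carbon only enters, and no measurement here explains the rise or divides it among these features.

Still open, going by these compounds, is whether the cyclobutyl ring, the loss of fluorine or the different chlorophenyl arrangement accounts for most of the step. A 3-chlorobenzyl or 1-(3-chlorophenyl)ethyl group on the same nitrogen would help separate these features, and a 1-(3-chlorophenyl)cyclopropyl group would test how much of the step follows the size of the carbon ring.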